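A few compounds are considered here, and "the series" means these few. Any claim that something is new, unique, unknown or untested is made for them only; others in the source may bear on it.

Among the compounds with values here, in a physicochemical assay for lipophilicity, measured as octanol-water partition (a higher number here means a more lipophilic compound, a lower number a more polar compound), compound 1 `CCCN(CCC)c1c([N+](=O)[O-])cc(Sc2cc(C)c(Cl)cc2Cl)cc1[N+](=O)[O-]` gives 8.66, the highest of the three numbers measured so far. Compound 3 `O=[N+]([O-])c1cc([N+](=O)[O-])c(S(=O)(=O)Nc2cccc(F)c2)c(C(F)(F)F)c1` gives 4.39 in this assay, a number well beyond the scatter below compound 1, and compound 2 `N#Cc1cc([N+](=O)[O-])c(S(=O)(=O)Nc2cccc(F)c2)c([N+](=O)[O-])c1` gives 2.51, further still below it. Compound 4 `CCCN(CCC)c1c([N+](=O)[O-])cc(Sc2ccc(OC)cc2)cc1[N+](=O)[O-]` has not been measured yet. It differs from compound 1 by 4-methoxyphenyl in place of 2,4-dichloro-5-methylphenyl on a sulfur. Within the data shown here, no measured pair shows this exact change, so the expectation rests on the structures alone: a sizeable drop, clearly beyond the scatter, is expected in this assay. Starting from compound 1 at 8.66, the expected step is a number 2.06 log units lower from compound 1 to compound 4 (beyond the scatter). Compound 4 is therefore expected to give 6.6 in this assay, most likely between 5.8 and 7.4.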

Compound 4, partition coefficient: 6.53
Compound 4: the middle estimate sits 0.07 log units above what was measured, and the stated range covers the measured number.
By their numbers in this assay, from the lowest: compound 2; then compound 3; then compound 4; then compound 1.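

Within the data shown here, replacing 2,4-dichloro-5-methylphenyl with 4-methoxyphenyl on the sulfur gives the first single-place step in this assay, a number 2.13 log units lower from compound 1 to compound 4 (beyond the scatter), showing that the group at this place can move the number well beyond the scatter. The swap removes both chlorines and the methyl and brings in the methoxy all at once, so this single step cannot be divided among those changes. Nothing available explains its size.

Whether the chlorines, the methyl or the methoxy accounts for most of the step remains open. Also open, as far as these compounds go, is what a plain phenyl ring or a carboxylic acid on that ring would give.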